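Compound 1 to compound 3: isopropyl in place of methyl

A few compounds are considered here, and "the series" means these few. Any claim that something is new, unique, unknown or untested is made for them only; others in the source may bear on it.

Compound 1 `C/C(=N/c1ccnc2cc(Cl)ccc12)NC1CCN(Cc2ccccc2)CC1` serves as the starting point. In an ADME assay (liver, Mus musculus) for metabolic stability, read by LC-MS, using microsomes, tested at 1 uM (a higher number here means that the compound lasts longer, a lower number that the compound disappears faster), compound 1 gives > 1 h, a limit and not a number. Compound 2 `C/C(=N/c1ccnc2cc(Cl)ccc12)NC1CCN(C)CC1` gives > 1 h, also a limit. For the measured compounds named here, the series so far shows (the limit of > 1 h in this assay, at which 2 of the 2 values shown sit), so compound 1 has no exact place on the scale.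

Compound 3 `CC(C)/C(=N/c1ccnc2cc(Cl)ccc12)NC1CCN(Cc2ccccc2)CC1` keeps the core of compound 1 and carries isopropyl in place of methyl on a carbon with a double bond to nitrogen. Going by the values given here, the one measured step, a step that the two limits leave unreadable from compound 1 to compound 2, concerns hydrogen in place of phenyl on a saturated chain carbon bound to an amine nitrogen in a ring, so it does not test this change. On that basis, no step beyond the scatter is expected in this assay, and no direction can be assigned. The expected step is a step that the limit leaves unreadable from compound 1 to compound 3. Compound 3 is estimated at 1.5 h, with an expected range of 0.7 h to 3 h.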

Compound 3, half-life: 0.5 h
Compound 3: the middle estimate sits 3.0-fold (0.48 log units) above what was measured, and the stated range ends above it.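

This position is the only place in the series where a change can be read: isopropyl in place of methyl on a carbon with a double bond to nitrogen gives an at least 2.0-fold lower number from compound 1 to compound 3 (0.30 log units; that floor lies within the scatter) in this assay. The direction is downward, but only a floor on the size is known, and that floor does not by itself place the change beyond the scatter. Compound 3, at 0.5 h, carries the only value in the series that is a number and not a limit: the limit of > 1 h in this assay, at which 2 of the 3 values shown sit.

The step from compound 1 to compound 2 cannot be read. Open, going by these compounds, are how ethyl or cyclopropyl would read on this same carbon, and whether isopropyl in place of methyl would give a readable step on compound 2 as well.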